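The source may hold more compounds than are shown below. What is called first, only, known or untested is meant among the compounds shown, and "the series" means these compounds.

Two compounds have been measured:
compound 1, `CNC(=O)c1cc(Oc2ccc(C(=O)/C=C/c3cc(OC)c(OC)c(OC)c3)cc2)ccn1`, with 9500 nM in a functional assay on A549 cells (Homo sapiens) for cytotoxicity, read by MTT assay, with a stated time of 72 h; a lower number here means a stronger inhibitor, a higher number a weaker inhibitor;
compound 2, `CNC(=O)c1cc(Oc2ccc(C(=O)/C=C/c3cccc(Br)c3)cc2)ccn1`, with 9940 nM in this assay.

Compound 2 has the higher of the two numbers in this assay, but its nearest neighbour, compound 1, sits within the scatter of it, so the two cannot be told apart on these numbers. Compound 3, `CNC(=O)c1cc(Oc2ccc(C(=O)/C=C/c3ccc(Br)cc3)cc2)ccn1`, has not yet been tested in this assay. It keeps the same atoms as compound 2, joined differently: 4-bromophenyl in place of 3-bromophenyl on a double-bonded chain carbon bound to a double-bonded chain carbon. Among the measured compounds shown here, no step between two measured compounds is known here, so the expectation rests on compound 2 alone. Exchanging 3-bromophenyl for 4-bromophenyl is a small change, and the expected step is small, in either direction, and probably not beyond the scatter: a 1.1-fold lower number from compound 2 to compound 3 (0.04 log units; within the scatter). Compound 3 is therefore estimated at 9000 nM in this assay, with a range from 3000 nM to 30000 nM.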

Compound 3, half-maximal inhibitory concentration: > 50000 nM
Compound 3: only a limit was reported; the forecaster's own chance of this, stated with the estimate: 15%; at least 5.5-fold (0.74 log units) between middle value and limit.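

For compound 3, the reading in this assay is > 50000 nM, which is a limit of the assay and not a number. Among the compounds shown here, exchanging 3-bromophenyl for 4-bromophenyl on a double-bonded chain carbon bound to a double-bonded chain carbon gives an at least 5.0-fold higher number from compound 2 to compound 3 (0.70 log units; beyond the scatter), so the same atoms, joined differently, produce a step beyond the scatter, which no earlier compound could show. The true size of this step stays unknown, and only its lower bound can be read, because the result for compound 3 is a limit: the limit of > 50000 nM in this assay, at which 1 of the 3 values shown sits.

What the compounds shown leave open is whether this loss is tied to bromine itself or would also appear with another group at that spot, such as 4-chlorophenyl or 4-aminophenyl. They also give no reason for the step.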